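Bare Phenyl in Place of a Fluoro-Methoxy Ring

The compounds below may be only part of what the source reports. "The series", "measured", "known", "first", "only" and "open" are said of these compounds alone.

Within the data shown here, compound 2 `COc1ccc(F)cc1N1C(=O)CSC1c1cccc(C(=O)NCCCCc2ccccc2)c1` stands highest of the two compounds measured so far. In a functional assay on 143B cells (Homo sapiens) for inhibition, read by CCK-8 assay, with a stated time of 72 h, tested at 1 uM (a lower number here means less inhibition, a higher number more inhibition at the concentration tested (going by the name of the read-out)), compound 2 gives 62%, whereas compound 1 `COc1ccc(OC)c(N2C(=O)CSC2c2cccc(C(=O)NCCCCc3ccccc3)c2)c1` gives 2%. Among the measured compounds shown here, the one measured step, a number 60 percentage points higher from compound 1 to compound 2 (beyond the scatter), shows that exchanging a single group on the ring attached to the amide-type nitrogen in a ring shifts the read-out by a large amount.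

Compound 3 `O=C(NCCCCc1ccccc1)c1cccc(C2SCC(=O)N2c2ccccc2)c1` carries phenyl in place of 5-fluoro-2-methoxyphenyl on an amide-type nitrogen in a ring. For the measured compounds named here, this removes the fluorine as well as the methoxy, so no measured compound mirrors it exactly. The step of a number 60 percentage points higher from compound 1 to compound 2 (beyond the scatter) bears on it and was large, so a large shift is plausible here too. A drop is expected, a number 37 percentage points lower from compound 2 to compound 3 (beyond the scatter), because compound 1 gives 2% without the fluorine, though the missing methoxy leaves the size open. Compound 3 is therefore estimated at 25%, within a range from 0% to 60%.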

Compound 3, a percentage reported as inhibition, at one concentration (the size of the read-out at that concentration, not a potency): 60%
Estimate against measurement, compound 3: 35 percentage points below; the range from low to high includes it.
By their numbers in this assay, from the lowest: compound 1; then compounds 3 and 2 (each within the scatter of the next).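

In this assay the bare phenyl gives a number 2 percentage points lower from compound 2 to compound 3 (within the scatter) so on this amide-type nitrogen, the 5-fluoro-2-methoxyphenyl group and an unsubstituted ring cannot be told apart. Set against the 2,5-dimethoxyphenyl group, the same phenyl gives a number 58 percentage points higher from compound 1 to compound 3 (beyond the scatter) which shows that a ring with no added groups is enough for a large read-out here, and that of these three compounds only compound 1 stands apart. No measurement at hand explains this difference.

From the compounds shown here alone, compound 3 lacks both the fluorine and the methoxy of compound 2, so the separate effect of each group stays unknown, and it also stays unknown which methoxy of compound 1 matters. A phenyl carrying a single methoxy, an amine or a carboxylic acid at this position would be needed to test these questions.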